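This account rests on a few compounds, and the source may have more. Where it says the series, first, only, none or still open, it means among the compounds named here.

Working notes on the series. The shared core carries an amide on the aryl ring, and the three measured compounds differ only in the group on the saturated chain carbon bound to the carbonyl carbon. In a functional assay on MCF7 cells (Homo sapiens) for cytotoxicity, read by MTT assay, with a stated time of 24 h, tested at 0.64 ug/mL (a higher number here means a stronger effect of the compound at the concentration tested, a lower number a weaker effect), compound 1 `Cn1c(-c2ccc(NC(=O)CCl)cc2)nc(-c2ccccc2)c1-c1ccccc1` gives 3.4%, compound 2 `Cn1nnnc1SCC(=O)Nc1ccc(-c2nc(-c3ccccc3)c(-c3ccccc3)n2C)cc1` gives 21.9%, and compound 3 `CCN1CCN(CC(=O)Nc2ccc(-c3nc(-c4ccccc4)c(-c4ccccc4)n3C)cc2)CC1` gives 4.7%. The measured steps are a number 18.5 percentage points higher from compound 1 to compound 2 (beyond the scatter), a number 1.3 percentage points higher from compound 1 to compound 3 (within the scatter) and a number 17.2 percentage points lower from compound 2 to compound 3 (beyond the scatter). Compound 3 thus stands second highest of the three numbers; its nearest neighbour is compound 1, within the scatter, and its furthest is compound 2, beyond the scatter.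

Compound 4 `COc1ccc(CN2CCN(CC(=O)Nc3ccc(-c4nc(-c5ccccc5)c(-c5ccccc5)n4C)cc3)CC2)cc1` differs from compound 3 at a different place: 4-methoxyphenyl in place of methyl on a saturated chain carbon bound to an amine nitrogen in a ring. Among the measured compounds shown here, no measured step touches the substituent on the ring amine nitrogen, so none bears directly on this change. The steps that do exist, all at the chain carbon bound to the carbonyl, range from within the scatter to modest. For the measured compounds named here, with no direct precedent, the step is expected to be small: a number 3.3 percentage points higher from compound 3 to compound 4 (within the scatter), as an estimate and not a measurement. For compound 4 the value in this assay is therefore estimated at 8%, with a range from 0% to 25%.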

Compound 4, a percentage reported as activity, at one concentration (the size of the read-out at that concentration, not a potency): 1%
For compound 4 the middle estimate is 7 percentage points above the measured one; the measured number falls inside the stated range.
By their numbers in this assay, from the lowest: compounds 4, 1 and 3 (each within the scatter of the next); then compound 2.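

In this assay, among the compounds shown here, the one measured change on the saturated chain carbon bound to an amine nitrogen in a ring gives a number 3.7 percentage points lower from compound 3 to compound 4 (within the scatter). Replacing methyl with 4-methoxyphenyl, which brings in a six-membered aromatic ring of carbon only and a hydrogen-bond acceptor, therefore leaves compound 3 and compound 4 within the scatter of each other, so ethyl and 4-methoxybenzyl on the ring amine are not told apart at this single concentration. No measured property of these compounds bears on this result.

From the compounds shown here alone, it remains open whether a different group at this place, such as a carboxylic acid or a primary amine, would give a step beyond the scatter. Going by these compounds, it is also open whether a longer chain between the ring amine nitrogen and the aromatic ring would do so.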